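The source may report more compounds than this note shows. Statements on the series, on what has been measured and on what is new or still open speak of the compounds shown alone.

Measured in a functional assay on Caco-2 cells (Homo sapiens) for cytotoxicity, read by MTT assay, with a stated time of 48 h; a lower number here means a stronger inhibitor, a higher number a weaker inhibitor:
- Compound 1 `O=C(/C=C(/C=C/c1ccc(O)cc1)NCCCO)/C=C/c1ccc(O)cc1`: 31600 nM
- Compound 2 `COc1cc(/C=C/C(=O)/C=C(/C=C/c2ccc(O)c(OC)c2)NCCCO)ccc1O`: 75700 nM
- Compound 3 `COCCNC(=C\C(=O)/C=C/c1ccc(O)c(OC)c1)/C=C/c1ccc(O)c(OC)c1`: > 100000 nM, a limit of the assay and not a number

Going by the values given here, only two of these readings are actual numbers. Compound 1 holds the lower of them, and the gap up to compound 2 lies beyond the usual scatter.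

The next compound to be tested, compound 4 `COCCCNC(=C\C(=O)/C=C/c1ccc(O)cc1)/C=C/c1ccc(O)cc1`, differs from compound 1 by one change, (methyl in place of hydrogen on an oxygen on a saturated carbon). This is methyl in place of hydrogen on an oxygen on a saturated carbon, or hydroxy to methoxy.

Among the compounds with values here, one measured step bears on this change: an at least 1.3-fold higher number from compound 2 to compound 3 (0.12 log units; that floor lies within the scatter). It is only a partial match, since it replaces hydroxymethyl with methoxy on a saturated chain carbon and starts from compound 2 rather than compound 1. Its size is also only a floor, because compound 3 ends at the limit of the assay, as the limit of > 100000 nM in this assay, at which 1 of the 3 values shown sits, records.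

That floor points to a small rise in this assay at best, and no step beyond the scatter is firmly expected. The expected change is estimated as a 1.5-fold higher number from compound 1 to compound 4 (0.18 log units; within the scatter). For compound 4 the estimated value is 48000 nM, with an expected range from 22000 nM to 100000 nM.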

Compound 4, half-maximal inhibitory concentration in the Caco-2 assay: 24000 nM
Compound 4: the middle estimate sits 2.0-fold (0.30 log units) above what was measured; the range from low to high includes it.
By their numbers in the Caco-2 assay, from the lowest: compounds 4 and 1 (each within the scatter of the next); then compound 2. At a limit, above all of these: compound 3.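

Set in the Caco-2 assay, the change from hydroxy to methoxy on this chain gives a 1.3-fold lower number from compound 1 to compound 4 (0.12 log units; within the scatter), so methyl in place of hydrogen on this oxygen leaves the reading within the scatter. Going by these compounds alone, the one earlier step that bore on this position could give only a floor, and it was a different change on a different core, whereas here both ends of the step are real numbers and the same single change is read directly. The change does register in a physicochemical assay for solubility, using the shake flask method, in phosphate buffer, with a stated time of 90 min, at pH 6.8 (a higher number here means a more soluble compound, a lower number a less soluble compound), where compound 1 gives 137000 nM and compound 4 gives 10500 nM, and the methoxy compound shows far less in solution: the measured solubility of compound 1, 137000 nM, and of compound 4, 10500 nM, a 13-fold lower number (1.12 log units; beyond the scatter)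

The compounds shown leave open whether an amine or a carboxylic acid in place of the hydroxy, or a longer chain, would move the reading in the Caco-2 assay beyond the scatter. They also leave open whether methyl on this oxygen acts the same way on the core of compound 2, since the nearest comparison there, compound 3, stands at a limit of the assay and not at a number.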